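Working notes on tolerability across compounds 1 to 4

This account rests on a few compounds, and the source may have more. Where it says the series, first, only, none or still open, it means among the compounds named here.

Four compounds share one core: compound 1 `O=C(O)CCC(=O)Nc1ccc(-c2nc3cc(C(F)(F)F)ccc3[nH]2)cc1`, compound 2 `CC(=O)Nc1ccc(-c2nc3ccccc3[nH]2)cc1`, compound 3 `CC(=O)Nc1ccc(-c2nc3cc(C(F)(F)F)ccc3n2C2CCCCC2)cc1` and the not yet measured compound 4 `CC(=O)Nc1ccc(-c2nc3cc(C(F)(F)F)ccc3[nH]2)cc1`. In an ADME assay on BHK cells (Mesocricetus auratus) for cytotoxicity, read by MTT assay, with a stated time of 96 h (a higher number here means that more compound is tolerated, a lower number that less compound is tolerated), compound 3 gives 15000 nM. For the measured compounds named here, that is the only number reported for the series in this assay. For compound 1 this assay reports a limit, > 100000 nM. For compound 2 this assay reports a limit as well, > 100000 nM. Going by the values given here, compound 3 therefore stands alone as the one compound with a measured concentration, while the other two sit at the limit of > 100000 nM in this assay, at which 2 of the 3 values shown sit.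

From compound 3 to compound 4 the change is hydrogen in place of cyclohexyl on an aromatic nitrogen. Among the compounds with values here, no measured step between two compounds covers this exact change, so the expectation rests on what the two limits show. Compound 1 and compound 2 both carry hydrogen at this position and both sit at the limit, whereas compound 3, carrying the cyclohexyl, gives a number. The expected step in this assay from compound 3 to compound 4 is upward, by a 6.7-fold higher number from compound 3 to compound 4 (0.82 log units; beyond the scatter), beyond the scatter. Compound 4 is estimated at 100000 nM, with a range from 30000 nM to 300000 nM, and a limit rather than a number is a real possibility for compound 4.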

Compound 4, half-maximal cytotoxic concentration: 53000 nM
Compound 4: middle estimate off by 1.9-fold (0.28 log units), on the high side; the range from low to high includes it.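

In this assay hydrogen in place of cyclohexyl on an aromatic nitrogen now has a size between two actual numbers, a 3.5-fold higher number from compound 3 to compound 4 (0.55 log units; beyond the scatter) and so a change that lies beyond the scatter. Taking away the cyclohexyl does not by itself bring a compound to the limit, as compound 4 still gives a number, whereas two compounds with hydrogen at this nitrogen report only a limit: (the limit of > 100000 nM in this assay, at which 2 of the 4 values shown sit). The comparisons with those two compounds stay loose, with an at least 1.8-fold lower number from compound 2 to compound 4 (0.27 log units; that floor lies within the scatter) for trifluoromethyl in place of hydrogen on an aromatic carbon and an at least 1.8-fold lower number from compound 1 to compound 4 (0.27 log units; that floor lies within the scatter) for hydrogen in place of carboxymethyl on a saturated chain carbon bound to a carbonyl carbon, and neither floor clears the scatter.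

Only cyclohexyl and hydrogen are shown on this nitrogen, so it remains open where a methyl group, a longer chain or a phenyl ring would fall. Also open, on these data alone, is how a chlorine atom or a methoxy group in place of the trifluoromethyl would read in this assay against compound 4 on the same core.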